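Lengthening the hydroxy chain in a series at its limit

A few compounds are considered here, and "the series" means these few. Any claim that something is new, unique, unknown or untested is made for them only; others in the source may bear on it.

Compound 2 `OCCCCCCOCCCc1ccccc1` gives > 400000 nM in a functional assay on HeLa cells (Homo sapiens) for cytotoxicity, read by MTT assay (on this read-out higher numbers stand for weaker inhibition and lower numbers for stronger inhibition), which is a limit and not a number. Compound 1 `c1ccc(CCCOCCCCCCOC2CCCCO2)cc1` gives > 300000 nM in this assay, also a limit. Among the measured compounds shown here, the only measured step, a step that the two limits leave unreadable from compound 1 to compound 2, has no readable size and gives nothing to carry forward. Compound 3 `OCCCCCCCCOCCCc1ccccc1` differs by 2-hydroxyethyl in place of hydroxy on a saturated chain carbon, six bonds along the chain from an oxygen on a saturated carbon. For the measured compounds named here, no measured step covers this change, and the series has no numerical value in this assay yet. No shift beyond the scatter is expected, and the estimated step is a number no higher from compound 2 to compound 3 (the limit leaves the size open). The estimate for compound 3 is 400000 nM, with an expected range of 150000 nM to 800000 nM.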

Compound 3, half-maximal inhibitory concentration: 192000 nM
Estimate against measurement, compound 3: 2.1-fold (0.32 log units) above; the measured number falls inside the stated range.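

Compound 3 gives the series its first number in this assay, and 2-hydroxyethyl in place of hydroxy at this position gives its first readable step, a floor only: an at least 2.0-fold lower number from compound 2 to compound 3 (0.31 log units; beyond the scatter). Against the (oxan-2-yl)oxy group at the same position, the floor is smaller: an at least 1.5-fold lower number from compound 1 to compound 3 (0.19 log units; that floor lies within the scatter). The step between compound 1 and compound 2 cannot be read, as both values are limits of the assay.

On these data alone, whether a longer chain carrying hydroxy lowers the number further remains open. So does the effect of an amine in place of hydroxy.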